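Imidazolyl for Dimethylamino on a Second Core

The source may hold more compounds than are shown below. What is called first, only, known or untested is meant among the compounds shown, and "the series" means these compounds.

Compound 1 `CN(C)c1ccc(Nc2nccc(-c3ccco3)n2)cc1` gives 1900 nM in a functional assay for inhibition, with Homo sapiens as the target; a lower number here means a stronger inhibitor, a higher number a weaker inhibitor. Compound 2 `c1coc(-c2ccnc(Nc3ccc(-n4ccnc4)cc3)n2)c1` carries the change 1H-imidazol-1-yl in place of dimethylamino on an aromatic carbon and gives 2200 nM in this assay, so that the step is a 1.2-fold higher number from compound 1 to compound 2 (0.06 log units; within the scatter). Compound 3 `CN(C)c1ccc(Nc2nccc(-c3ccncc3)n2)cc1` differs from compound 1 in its core by pyridin-4-yl in place of furan-2-yl on an aromatic carbon; in this assay compound 3 gives 3700 nM, and the step is a 1.9-fold higher number from compound 1 to compound 3 (0.29 log units; within the scatter). All three values lie within the scatter of one another, so none of the three can be ranked against the others.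

Compound 4 `c1cc(-c2ccnc(Nc3ccc(-n4ccnc4)cc3)n2)ccn1` has not yet been measured. It differs from compound 3 by 1H-imidazol-1-yl in place of dimethylamino on an aromatic carbon, the same change, at the same place, that separates compound 2 from compound 1; this change occurs twice among the four compounds. Because the earlier instance gave only a 1.2-fold higher number from compound 1 to compound 2 (0.06 log units; within the scatter), a step within the scatter, the step from compound 3 to compound 4 is expected to be of like size, a 1.2-fold higher number from compound 3 to compound 4 (0.08 log units; within the scatter). Compound 4 is therefore expected to give about 4400 nM in this assay, most likely between 1500 nM and 13000 nM.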

Compound 4, half-maximal inhibitory concentration: 7600 nM
For compound 4 the middle estimate is 1.7-fold (0.24 log units) below the measured one; measured number inside the range.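

In this assay, 1H-imidazol-1-yl in place of dimethylamino gives a 2.1-fold higher number from compound 3 to compound 4 (0.31 log units; beyond the scatter), and this step cannot be told apart from the earlier one on the core of compound 1: the same change on two cores in this assay, a 1.2-fold higher number (0.06 log units; within the scatter) from compound 1 to compound 2 and a 2.1-fold higher number (0.31 log units; beyond the scatter) from compound 3 to compound 4, 1.8-fold (0.25 log units) apart, within the scatter of two such steps. The second change, pyridin-4-yl in place of furan-2-yl, gives a 3.5-fold higher number from compound 2 to compound 4 (0.54 log units; beyond the scatter), and it too matches its earlier counterpart: the same change on two cores in this assay, a 1.9-fold higher number (0.29 log units; within the scatter) from compound 1 to compound 3 and a 3.5-fold higher number (0.54 log units; beyond the scatter) from compound 2 to compound 4, 1.8-fold (0.25 log units) apart, within the scatter of two such steps. Both changes therefore carried from one partner to the other without a difference that stands clear of the scatter, though each comparison rests on a single pair of steps, both new steps are modest, and nothing here shows that either change would carry the same way to any further core.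

The compounds shown hold only dimethylamino or 1H-imidazol-1-yl on the six-membered aromatic ring of carbon only, so it remains open whether a morpholine or a carboxylic acid there would follow the same steps. Going by these compounds, it also remains open how a thiophene in place of furan-2-yl or pyridin-4-yl would compare.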